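Chain-end variation on the shared core

The compounds below may be only part of what the source reports. "The series", "measured", "known", "first", "only" and "open" are said of these compounds alone.

compound 1 `FC(F)(F)Cc1nnc2c(Cl)c(N3CCC(c4ccccc4)CC3)ccn12` — 55 nM
compound 2 `Clc1c(N2CCC(c3ccccc3)CC2)ccn2c(CC3CC3)nnc12` — 102 nM

In a functional assay on CHO cells for positive allosteric modulation of metabotropic glutamate receptor 2 (Homo sapiens), read by GTPgammaS binding, with a stated time of 30 min (on this read-out higher numbers stand for an effect only at larger amounts of compound and lower numbers for an effect already at smaller amounts), compound 1 gives 55 nM, and compound 2 gives 102 nM. Compound 2 carries the higher of the two numbers, but the step of a 1.9-fold higher number from compound 1 to compound 2 (0.27 log units; within the scatter) stays within the scatter, so the two compounds are not separated. Compound 3 `CCc1nnc2c(Cl)c(N3CCC(c4ccccc4)CC3)ccn12` differs from compound 2 by methyl in place of cyclopropyl on a saturated chain carbon bound to an aromatic carbon. Among the compounds with values here, the only measured step touching this place is a 1.9-fold higher number from compound 1 to compound 2 (0.27 log units; within the scatter), which exchanged trifluoromethyl for cyclopropyl with no change beyond the scatter. The evidence at this place is thin: a single step, and a small one. For compound 3 the expected step is a 1.3-fold higher number from compound 2 to compound 3 (0.11 log units; within the scatter), in no direction beyond the scatter. Compound 3 is estimated at 130 nM, with a range from 50 nM to 350 nM.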

Compound 3, half-maximal effective concentration: 386 nM
For compound 3 the middle estimate is 3.0-fold (0.47 log units) below the measured one; measured number above the stated range.
By their numbers in this assay, from the lowest: compounds 1 and 2 (each within the scatter of the next); then compound 3.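

Replacing the end group at this place on a saturated chain carbon bound to an aromatic carbon is not neutral, as the earlier pair alone suggested: in this assay methyl separates from both cyclopropyl (a 3.8-fold higher number from compound 2 to compound 3 (0.58 log units; beyond the scatter)) and trifluoromethyl (a 7.0-fold higher number from compound 1 to compound 3 (0.85 log units; beyond the scatter)). Cyclopropyl and trifluoromethyl remain within the scatter of each other, so the two steps to compound 3 mark methyl as the only end group set apart among the three shown. No measurement bearing on the origin of this difference is available.

As far as these compounds go, whether a longer chain such as propyl would stay with compound 1 and compound 2 or with compound 3 remains open. Also open, from the compounds shown here alone, is how an end group carrying an amine or a carboxylic acid would fare at this place, and whether these steps hold on any other core.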